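The source may hold more compounds than are shown below. What is called first, only, known or untested is meant among the compounds shown, and "the series" means these compounds.

Measured compounds:
compound 1 `COc1cc(-c2nn(-c3cccc(NC(=O)Nc4cc(C(F)(F)F)cc(C(F)(F)F)c4)c3)cc2-c2ccncc2)ccc1Cl`, 1310 nM
compound 2 `O=C(Nc1cccc(-n2cc(-c3ccncc3)c(-c3ccc(Cl)c(O)c3)n2)c1)Nc1cc(C(F)(F)F)cc(C(F)(F)F)c1`, 1250 nM
compound 3 `COc1cc(-c2nn(-c3cccc(NC(=O)Nc4ccc(Cl)c(C(F)(F)F)c4)c3)cc2-c2ccncc2)ccc1Cl`, 1500 nM

All three were run in a functional assay on DU-145 cells (Homo sapiens) for inhibition, read by sulforhodamine B assay, with a stated time of 48 h; on this read-out lower numbers stand for stronger inhibition of growth and higher numbers for weaker inhibition of growth. Compound 1 gives 1310 nM, compound 2 gives 1250 nM and compound 3 gives 1500 nM. The three numbers sit close together, and none of the gaps between them is wide enough to be read as a difference in growth inhibition.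

The change from compound 1 to compound 2 is hydrogen in place of methyl on an oxygen on an aromatic ring. It produced a 1.0-fold lower number from compound 1 to compound 2 (0.02 log units; within the scatter), so on this pair the change left the read-out essentially where it was.

Compound 4 `O=C(Nc1cccc(-n2cc(-c3ccncc3)c(-c3ccc(Cl)c(O)c3)n2)c1)Nc1ccc(Cl)c(C(F)(F)F)c1` has not yet been measured in this assay. It stands to compound 3 as compound 2 stands to compound 1: the change from compound 3 to compound 4 is hydrogen in place of methyl on an oxygen on an aromatic ring, and the place of the change reads the same in both pairs, so this is the same change made on a second core. How the core of compound 3 differs from that of compound 1 is not broken down here.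

Within the data shown here, the expectation for compound 4 rests on the one measured example of this change, which gave a 1.0-fold lower number from compound 1 to compound 2 (0.02 log units; within the scatter), together with compound 3 at 1500 nM. On that basis the step from compound 3 to compound 4 is expected to be a 1.0-fold lower number from compound 3 to compound 4 (0.01 log units; within the scatter), a step within the usual scatter. Compound 4 is accordingly estimated to give about 1450 nM in this assay, with a likely range from 700 nM to 3000 nM.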

Compound 4, concentration for 50% growth inhibition: 1130 nM
For compound 4 the middle estimate is 1.3-fold (0.11 log units) above the measured one; the measured number falls inside the stated range.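

The methoxy to hydroxy change, made on a second core in this assay, gave a 1.3-fold lower number from compound 3 to compound 4 (0.12 log units; within the scatter), so the 4-chloro-3-hydroxyphenyl compound could not be told apart from its 4-chloro-3-methoxyphenyl partner on this read-out. Set beside the earlier pair, the change carried over from one core to the other without a detectable difference in its size: the same change on two cores in this assay, a 1.0-fold lower number (0.02 log units; within the scatter) from compound 1 to compound 2 and a 1.3-fold lower number (0.12 log units; within the scatter) from compound 3 to compound 4, 1.3-fold (0.10 log units) apart, within the scatter of two such steps This shows that, on these two cores and in this one cell assay, swapping methyl for hydrogen on that oxygen left growth inhibition where it was, but two pairs that both stay within the scatter cannot show that the same would hold on every core in the series, or that the two steps are truly identical rather than merely too small to separate.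

The compounds shown leave open whether an ethoxy group, an amine or a carboxylic acid in place of the methoxy would also leave the read-out unmoved. They also leave open whether the methoxy to hydroxy step would stay this small on a core carrying a nitrile or a methyl group in place of the trifluoromethyl groups.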